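A few compounds are considered here, and "the series" means these few. Any claim that something is new, unique, unknown or untested is made for them only; others in the source may bear on it.

Series notes. Compound 1 `Cn1c(-c2ccccc2)nc2c(NC3CCCC3)ncnc21` is the unsubstituted parent; in a functional assay on CHO cells for antagonist activity at adenosine receptor A2b (Homo sapiens), read by 33P incorporation, with a stated time of 20 min (a lower number here means a stronger inhibitor, a higher number a weaker inhibitor), compound 1 gives 8510 nM. Compound 2 `Cn1c(-c2cccc(Cl)c2)nc2c(NC3CCCC3)ncnc21` gives 2530 nM, the step being a 3.4-fold lower number from compound 1 to compound 2 (0.53 log units; beyond the scatter). Compound 3 `Cn1c(-c2ccc(C(=O)O)cc2)nc2c(NC3CCCC3)ncnc21` gives only a limit, > 30000 nM, so its true number is not known. It stands at the limit of > 30000 nM in this assay, at which 1 of the 3 values shown sits, and the step of an at least 3.5-fold higher number from compound 1 to compound 3 (0.54 log units; beyond the scatter) is therefore only a lower bound on the loss. Compound 4 `COc1ccc(-c2nc3c(NC4CCCC4)ncnc3n2C)cc1` is not yet measured; it differs from compound 3 by methoxy in place of carboxy on an aromatic carbon. Among the compounds with values here, no measured step covers methoxy, but both substituent steps bear on it: the chloro step a 3.4-fold lower number from compound 1 to compound 2 (0.53 log units; beyond the scatter) gained modestly, the carboxy step an at least 3.5-fold higher number from compound 1 to compound 3 (0.54 log units; beyond the scatter) lost at least modestly. Removing the carboxy is expected to bring the number back near that of compound 1, with the methoxy itself uncertain. Compound 4 is therefore expected at 4500 nM, within 1500 nM to 15000 nM. The expected step is an at least 6.6-fold lower number from compound 3 to compound 4 (0.82 log units; beyond the scatter), a fall in the number.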

Compound 4, inhibition constant: > 30000 nM
Compound 4 gave a limit, no number; the forecaster's own chance of this, stated with the estimate: 10%; middle value at least 6.6-fold (0.82 log units) from the limit.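

In this assay compound 4 gives only a limit, yet the loss on this carbon no longer rests on carboxy alone: the steps are an at least 3.5-fold higher number from compound 1 to compound 4 (0.54 log units; beyond the scatter) and an at least 11-fold higher number from compound 2 to compound 4 (1.07 log units; beyond the scatter). Methoxy carries no hydrogen-bond donor, so the loss does not require the donor of carboxy. The step between the carboxy and methoxy compounds cannot be read because both sit at the limit: the limit of > 30000 nM in this assay, at which 2 of the 4 values shown sit.

As far as these compounds go, whether 3-methoxyphenyl would keep the gain of 3-chlorophenyl remains open. So does whether chloro, an amine or a longer chain such as ethoxy is tolerated in place of the 4-methoxy group.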